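The compounds below may be only part of what the source reports. "The series", "measured", "known", "first", "only" and "open" are said of these compounds alone.

Compound 3 `Fc1ccc(COc2cccc(-c3cn([C@H]4CN5CCC4CC5)nn3)c2)cc1` stands highest of the three numbers measured in an assay on HEK293 cells for displacement of a labelled ligand from Neuronal acetylcholine receptor; alpha4/beta2 (Homo sapiens), read by scintillation counting, with a stated time of 120 min (on this read-out higher numbers stand for weaker inhibition and lower numbers for stronger inhibition), at 6390 nM; compound 1 `Fc1ccc(COc2cccc(-c3cn([C@@H]4CN5CCC4CC5)nn3)c2)cc1` gives 537 nM, and compound 2 `FCCOc1cccc(-c2cn(C3CN4CCC3CC4)nn2)c1` gives 1960 nM. Among the compounds with values here, the only step measured between compounds differing in one place is a 12-fold higher number from compound 1 to compound 3 (1.08 log units; beyond the scatter), which follows from the fact that one of compounds 1 and 3 is drawn with a defined configuration and the other without, at the place where they differ. Compound 4 `Fc1cccc(-c2cn([C@H]3CN4CCC3CC4)nn2)c1` differs from compound 3 by fluoro in place of (4-fluorobenzyl)oxy on an aromatic carbon. Within the data shown here, no measured step touches this change, and compounds 2 and 3 differ in more than one place, so their values alone show only a spread among the weaker members. With nothing to anchor the change, compound 4 is expected to stay near compound 3, with an estimated step of a 1.3-fold higher number from compound 3 to compound 4 (0.10 log units; within the scatter) and wide uncertainty. Compound 4 is estimated at 8000 nM, between 2000 nM and 30000 nM.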

Compound 4, inhibition constant: 5200 nM
The estimate for compound 4 lay 1.5-fold (0.19 log units) above the measured number, and the stated range covers the measured number.
By their numbers in this assay, from the lowest: compound 1; then compound 2; then compounds 4 and 3 (each within the scatter of the next).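

In this assay, the step of a 1.2-fold lower number from compound 3 to compound 4 (0.09 log units; within the scatter) shows that, in the configuration of compound 3, fluoro can stand in place of (4-fluorobenzyl)oxy on this aromatic carbon without a change beyond the scatter. The earlier compounds had shown a large step only at the saturated ring carbon, not at this aromatic position. Nothing given here bears on why this replacement leaves the number within the scatter.
On these data alone, whether the same replacement would behave alike in the configuration of compound 1 remains open. So does the effect of an amine or a carboxylic acid on this aromatic carbon.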